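The source may report more compounds than this note shows. Statements on the series, on what has been measured and on what is new or still open speak of the compounds shown alone.

Measured compounds:
- compound 1 `CC(O)CSc1nc(NCc2ccc(-c3ccccn3)cc2)c2[nH]nc(C(C)C)c2n1` gives 62 nM in a functional assay on HT cells (Homo sapiens) for antiproliferative activity, read by fluorescence, with a stated time of 72 h; on this read-out lower numbers stand for stronger inhibition of growth and higher numbers for weaker inhibition of growth
- compound 2 `CC(C)c1n[nH]c2c(NCc3ccc(-c4ccccn4)cc3)nc(SCCNC(N)=O)nc12` gives 240 nM in this assay

Among the measured compounds shown here, compound 2 has the highest of the two numbers seen so far, which on this read-out means the weaker growth inhibition; the only step recorded is the one leading to it, a 3.9-fold higher number from compound 1 to compound 2 (0.59 log units; beyond the scatter).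

Compound 3 `CC(C)c1n[nH]c2c(NCc3ccc(-c4ccccn4)cc3)nc(SC3CCCCC3N)nc12` is not yet measured. It differs from compound 2 in one place: 2-aminocyclohexyl in place of 2-ureidoethyl on a sulfur. For the measured compounds named here, no measured pair shows this same exchange, so the recorded step from compound 1 to compound 2 bears on it only loosely, as the one example of swapping the group on that sulfur. That step was modest, and the present swap replaces a two-carbon chain carrying a urea with a ring carrying an amine. Without a closer precedent, no step beyond the scatter is expected, a shift of a 1.5-fold lower number from compound 2 to compound 3 (0.18 log units; within the scatter) being the estimate. Compound 3 is therefore expected at about 160 nM, within a range of 40 nM to 650 nM.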

Compound 3, concentration for 50% growth inhibition: 139 nM
Beside the measured number, compound 3's estimate is 1.2-fold (0.06 log units) above it; low and high end bracket the measured number.
By their numbers in this assay, from the lowest: compound 1; then compounds 3 and 2 (each within the scatter of the next).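

In this assay, putting 2-aminocyclohexyl in place of 2-ureidoethyl on this sulfur gives a 1.7-fold lower number from compound 2 to compound 3 (0.24 log units; within the scatter), so an open chain carrying a urea and a six-membered carbon ring carrying an amine cannot be told apart here. Measured against the 2-hydroxypropyl group, the same ring gives a 2.2-fold higher number from compound 1 to compound 3 (0.35 log units; beyond the scatter), a modest step, and compound 1 keeps the lowest number of the three. No measurement shown here accounts for these steps.

The compounds shown leave open whether the ring or the amine sets the number for compound 3: a plain cyclohexyl and an open 2-aminoethyl group on the same sulfur would pull those two apart. From the compounds shown here alone, how a carboxylic acid at the end of the chain, or a longer hydroxyalkyl chain, would read also remains open.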